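This account rests on a few compounds, and the source may have more. Where it says the series, first, only, none or still open, it means among the compounds named here.

Measured so far in an assay on HEK293 cells for displacement of a labelled ligand from 5-hydroxytryptamine receptor 6 (Homo sapiens), read by scintillation counting; on this read-out higher numbers stand for weaker inhibition and lower numbers for stronger inhibition:
compound 1 `O=S(=O)(c1ccc2cccnc2c1)n1cc(C2=CCNCC2)c2ccccc21` gives 7 nM
compound 2 `O=S(=O)(c1cncc2ccccc12)n1cc(C2=CCNCC2)c2ccccc21` gives 5 nM
compound 3 `COc1ccc2c(c1)c(C1=CCNCC1)cn2S(=O)(=O)c1ccc2ncccc2c1` gives 14 nM

Compound 3 holds the highest of the three numbers in this assay; compound 1 sits within the scatter of it, while compound 2 lies beyond the scatter below it. Compound 4 `COc1ccc2c(c1)c(C1=CCNCC1)cn2S(=O)(=O)c1cncc2ccccc12` is not yet measured. It differs from compound 3 by isoquinolin-4-yl in place of quinolin-6-yl on a sulfonyl sulfur. Going by the values given here, no step between measured compounds carries this change directly; compounds 1 and 2 differ from each other in the same two groups, and their values in this assay sit within the scatter of each other. On that showing no step beyond the scatter is expected here, in either direction. For compound 4 the expected value in this assay is 10 nM, with a range from 4 nM to 25 nM. The step from compound 3 to compound 4 is accordingly expected to be a 1.4-fold lower number from compound 3 to compound 4 (0.15 log units; within the scatter).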

Compound 4, inhibition constant: 3 nM
Beside the measured number, compound 4's estimate is 3.3-fold (0.52 log units) above it; the whole stated range lies above it.
By their numbers in this assay, from the lowest: compounds 4, 2, 1 and 3 (each within the scatter of the next, the first and the last beyond it).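

In this assay, isoquinolin-4-yl in place of quinolin-6-yl on a sulfonyl sulfur, with methoxy on the core, gives a 4.7-fold lower number from compound 3 to compound 4 (0.67 log units; beyond the scatter). Compounds 1 and 2, without methoxy, did not show such a step. Going by these compounds alone, with isoquinolin-4-yl in place, methoxy in place of hydrogen on an aromatic carbon gives only a 1.7-fold lower number from compound 2 to compound 4 (0.22 log units; within the scatter) and so no step that can be told from scatter. From the compounds shown here alone, whether the step between the two sulfonyl groups also appears with chloro or ethoxy in place of methoxy stays open. The data given offer no evidence on why the step appears with methoxy.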